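Replacing the hydroxyalkyl chain on sulfur: an expected outcome

A few compounds are considered here, and "the series" means these few. Any claim that something is new, unique, unknown or untested is made for them only; others in the source may bear on it.

Compound 2 `CC1=C(SCCCCCCO)C(=O)c2ccccc2C1=O` was tested in a functional assay on MES-SA cells (Homo sapiens) for inhibition; on this read-out higher numbers stand for weaker inhibition and lower numbers for stronger inhibition. In this assay compound 2 gives > 10000 nM, which is a limit of the assay rather than a number. Compound 1 `CC1=C(SCCCCO)C(=O)c2ccccc2C1=O` likewise gives > 10000 nM, also a limit. The step that the two limits leave unreadable from compound 1 to compound 2 is therefore not readable, as the limit of > 10000 nM in this assay, at which 2 of the 2 values shown sit, shows. Compound 3 `CC1=C(SC(C)C(C)O)C(=O)c2ccccc2C1=O` differs from compound 2 by 2-hydroxy-1-methylpropyl in place of 6-hydroxyhexyl on a sulfur. Among the compounds with values here, no measured step gives a readable size for this kind of change, so nothing beyond the scatter can be foreseen. The expected step is a step that the limit leaves unreadable from compound 2 to compound 3. Compound 3 is estimated at 15000 nM, within the range 4000 nM to 50000 nM.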

Compound 3, half-maximal inhibitory concentration: > 10000 nM
Compound 3 gave a limit, no number (the forecaster's own chance of this, stated with the estimate: 75%); the middle value does not contradict the limit.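

Compound 1, compound 2 and compound 3 all stop at an assay limit rather than a number, so no step among them can be read: the limit of > 10000 nM in this assay, at which 3 of the 3 values shown sit.

The compounds shown leave open whether any chain on the sulfur gives a countable inhibition in this assay.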